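From 3-methoxyphenyl to 3-chloro-4-methylphenyl on the shared core

The source may hold more compounds than are shown below. What is called first, only, known or untested is meant among the compounds shown, and "the series" means these compounds.

Of the compounds shown here, three with one shared core have numbers so far in a functional assay on KBVIN cells (Homo sapiens) for antiproliferative activity, read by sulforhodamine B assay, with a stated time of 3 days (on this read-out lower numbers stand for an effect already at smaller amounts and higher numbers for an effect only at larger amounts of compound), and they fall into two groups. Compound 1 (`CCC1=C(O)c2c(oc(-c3ccc(CC)cc3)cc2=O)C(CC)(CC)C1=O`) gives 0.07 uM in this test, compound 2 (`CCC1=C(O)c2c(oc(-c3ccc(F)cc3)cc2=O)C(CC)(CC)C1=O`) gives 1.85 uM in the same test, and compound 3 (`CCC1=C(O)c2c(oc(-c3cccc(OC)c3)cc2=O)C(CC)(CC)C1=O`) gives 1.22 uM there too.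

Compound 3 thus stands at the high end of the numbers. Compound 2 shares that end with it, with a 1.5-fold lower number from compound 2 to compound 3 (0.18 log units; within the scatter) as the measured difference. Compound 1 lies far off, as shown by a 17-fold higher number from compound 1 to compound 3 (1.24 log units; beyond the scatter) and by a 26-fold higher number from compound 1 to compound 2 (1.42 log units; beyond the scatter) on the fluoro side.

Compound 4 (`CCC1=C(O)c2c(oc(-c3ccc(C)c(Cl)c3)cc2=O)C(CC)(CC)C1=O`) puts 3-chloro-4-methylphenyl in place of 3-methoxyphenyl on an aromatic carbon next to the ring oxygen (3-chloro-4-methylphenyl in place of 3-methoxyphenyl on an aromatic carbon). Among the measured compounds shown here, no measured step makes this exact change. For the measured compounds named here, the two large steps both start from compound 1, the only measured compound with an alkyl group on this aromatic ring. Going by the values given here, the entering group also carries one, a methyl rather than an ethyl, and its chlorine has no measured counterpart. A moderate move towards compound 1 is therefore expected, covering only part of that distance.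

The expected change is a 4.1-fold lower number from compound 3 to compound 4 (0.61 log units; beyond the scatter) and it remains an estimate. For compound 4 the estimated value is 0.3 uM with an expected range from 0.06 uM to 1.5 uM in this assay.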

Compound 4, concentration for half-maximal effect: 2.15 uM
The estimate for compound 4 lay 7.2-fold (0.86 log units) below the measured number, and the stated range ends below it.
By their numbers in this assay, from the lowest: compound 1; then compounds 3, 2 and 4 (each within the scatter of the next).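

In this assay, putting 3-chloro-4-methylphenyl in place of 3-methoxyphenyl at this position gives a 1.8-fold higher number from compound 3 to compound 4 (0.25 log units; within the scatter), and replacing 4-fluorophenyl with the same group gives a 1.2-fold higher number from compound 2 to compound 4 (0.07 log units; within the scatter), so compound 4 joins compounds 2 and 3 in the high group. Among the compounds shown here, an alkyl group on this aromatic ring is therefore not enough to bring a compound close to compound 1: compound 4 carries a methyl group and goes against any such link, with a 31-fold higher number from compound 1 to compound 4 (1.49 log units; beyond the scatter) still marking a large step, and compound 1 with its 4-ethylphenyl group remains the only compound apart from the rest. Nothing measured here explains why the 4-ethylphenyl group stands apart from the other three groups in this test.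

Compound 4 brings its methyl group and chlorine in together, so the compounds shown cannot tell whether either one alone would leave the number in the high group or move it towards compound 1. On these data alone, it also remains open whether a longer chain such as propyl, or an amine, on this aromatic ring would group with compound 1 or with compounds 2, 3 and 4.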